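A Dibromo-Hydroxy Ring Replaces a Cyano Ring

The compounds below may be only part of what the source reports. "The series", "measured", "known", "first", "only" and "open" are said of these compounds alone.

In a functional assay on MCF7 cells (Homo sapiens) for cytotoxicity, read by MTT assay, with a stated time of 72 h (on this read-out higher numbers stand for weaker inhibition and lower numbers for stronger inhibition), compound 1 `O=C(/C=C/c1cccc(Cl)c1Cl)Nc1cc2c(Nc3ccc(F)c(Cl)c3)ncnc2cc1O[C@H]1CCOC1` gives 30100 nM and compound 2 `N#Cc1ccc(/C=C/C(=O)Nc2cc3c(Nc4ccc(F)c(Cl)c4)ncnc3cc2O[C@H]2CCOC2)cc1` gives 9830 nM as the lower of the two numbers. Compound 3 `O=C(/C=C/c1cc(Br)c(O)c(Br)c1)Nc1cc2c(Nc3ccc(F)c(Cl)c3)ncnc2cc1O[C@H]1CCOC1` carries 3,5-dibromo-4-hydroxyphenyl in place of the 4-cyanophenyl of compound 2, and 3,5-dibromo-4-hydroxyphenyl in place of 4-cyanophenyl on a double-bonded chain carbon bound to a double-bonded chain carbon counts what changes. Among the measured compounds shown here, the only measured step at this place is a 3.1-fold lower number from compound 1 to compound 2 (0.49 log units; beyond the scatter) and it was modest, though beyond the scatter. That single step gives no direction for a new group, so no change beyond the scatter is expected, and a 1.2-fold higher number from compound 2 to compound 3 (0.09 log units; within the scatter) is the estimated step. Compound 3 is estimated at 12000 nM with an expected range from 3500 nM to 35000 nM in this measurement.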

Compound 3, half-maximal inhibitory concentration: 30600 nM
Estimate against measurement, compound 3: 2.6-fold (0.41 log units) below, within the range that was stated.
By their numbers in this assay, from the lowest: compound 2; then compounds 1 and 3 (each within the scatter of the next).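

On the chain carbon at this place, this assay gives 3,5-dibromo-4-hydroxyphenyl in place of 4-cyanophenyl a 3.1-fold higher number from compound 2 to compound 3 (0.49 log units; beyond the scatter) and thus takes back the whole gain seen with 4-cyanophenyl. Set against 2,3-dichlorophenyl, the same ring gives a 1.0-fold higher number from compound 1 to compound 3 (0.01 log units; within the scatter) and so leaves the two compounds level, with 4-cyanophenyl the only one of the three rings that stands apart. Nothing available explains this difference.

From the compounds shown here alone, whether the nitrile itself sets compound 2 apart remains open, and so does how a ring carrying an amine or a carboxylic acid would read here.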